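A Halogen Swap, Then Two Methyl Groups

A few compounds are considered here, and "the series" means these few. Any claim that something is new, unique, unknown or untested is made for them only; others in the source may bear on it.

Compound 1 `S=C(Nc1ccccc1)N1N=C(c2ccc(Cl)cc2)CC1c1ccc2c(c1)OCCO2`: > 200000 nM, a limit of the assay
Compound 2 `S=C(Nc1ccccc1)N1N=C(c2ccc(Br)cc2)CC1c1ccc2c(c1)OCCO2`: 870 nM

Of the compounds shown here, two sharing one core have been tested in a functional assay on WM 266-4 cells (Homo sapiens) for antiproliferative activity, read by MTT assay, with a stated time of 48 h; a higher number here means a weaker inhibitor of growth, a lower number a stronger inhibitor of growth. For compound 1 the assay reports only a limit, > 200000 nM, not a number; this is the situation described by the limit of > 200000 nM in this assay, at which 1 of the 2 values shown sits. Among the measured compounds shown here, compound 2 gives 870 nM, the only real number so far. For the measured compounds named here, the single measured step, an at least 220-fold lower number from compound 1 to compound 2 (2.36 log units; beyond the scatter), is large.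

Compound 3 `Cc1ccc(C2=NN(C(=S)Nc3ccccc3)C(c3ccc4c(c3)OCCO4)C2)cc1C` is not yet measured. It differs from compound 2 in one place: 3,4-dimethylphenyl in place of 4-bromophenyl on a carbon with a double bond to nitrogen. Going by the values given here, the one measured step concerns a different exchange on a carbon with a double bond to nitrogen, so it bears on this change only loosely, though it shows that this position can move the result a great deal. Among the compounds with values here, with no closer precedent, a moderate loss of potency is expected, namely a 3.4-fold higher number from compound 2 to compound 3 (0.54 log units; beyond the scatter). For compound 3 the estimate is 3000 nM, with a range from 400 nM to 40000 nM.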

Compound 3, concentration for 50% growth inhibition: 70500 nM
The estimate for compound 3 lay 24-fold (1.37 log units) below the measured number; measured number above the stated range.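

In this assay, among the compounds shown here, swapping 4-bromophenyl for 3,4-dimethylphenyl brings an 81-fold higher number from compound 2 to compound 3 (1.91 log units; beyond the scatter) and so shows that, among the three compounds, only the one with 4-bromophenyl at this position reaches a high potency. Still, 3,4-dimethylphenyl is not the poorest choice here, since the exchange against 4-chlorophenyl gives an at least 2.8-fold lower number from compound 1 to compound 3 (0.45 log units; beyond the scatter) and places compound 3 between the other two. This second comparison rests on a limit of the assay for compound 1, not on a number: the limit of > 200000 nM in this assay, at which 1 of the 3 values shown sits.

What sets 4-bromophenyl apart cannot be told from these values alone. Also open, from the compounds shown here alone, is where a ring with a single methyl group, a methoxy group or an iodine atom in place of the bromine would fall, and whether an amine or a carboxylic acid on this ring would be tolerated.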